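A few compounds are considered here, and "the series" means these few. Any claim that something is new, unique, unknown or untested is made for them only; others in the source may bear on it.

In an assay on cells for inhibition of sodium- and chloride-dependent glycine transporter 1 (Homo sapiens) (a higher number here means that more compound is needed for the effect, a lower number that less compound is needed), three compounds built on a shared core have been measured. Compound 1 `Cc1cc(C(F)(F)F)ccc1C(=O)NC1(c2ccccc2)CCCN(C)C1` gives 320 nM, compound 2 `CN1CCCC(NC(=O)c2ccc(Cl)cc2Cl)(c2ccccc2)C1` gives 670 nM, and compound 3 `COc1cc(C(F)(F)F)cc(SC)c1C(=O)NC1(c2ccc(F)cc2)CCCN(C)C1` gives 26 nM. Compound 3 thus shows the lowest of the three numbers in this assay; the nearest of the others is compound 1, whose number is higher by a margin beyond the scatter, and the furthest is compound 2, whose number is higher still, also beyond the scatter.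

Compound 4 `COc1ccc(C2(NC(=O)c3c(OC)cc(C(F)(F)F)cc3SC)CCCN(C)C2)cc1` has not yet been measured in this assay. It differs from compound 3 in one place: methoxy in place of fluoro on an aromatic carbon. Going by the values given here, no step of this kind between two measured compounds is available, so the size of the change can only be expected rather than read off. On the compounds shown, compound 4 is expected to remain in the neighbourhood of the lowest number so far. The step is expected to be small, a 1.7-fold higher number from compound 3 to compound 4 (0.24 log units; within the scatter), leaning if anything toward a somewhat higher number. Compound 4 is therefore estimated at 45 nM in this assay, with a range from 15 nM to 130 nM.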

Compound 4, half-maximal effective concentration: 170 nM
Estimate against measurement, compound 4: 3.8-fold (0.58 log units) below; the measured number lies above the stated range.
By their numbers in this assay, from the lowest: compound 3; then compounds 4 and 1 (each within the scatter of the next); then compound 2.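

In this assay, going by these compounds alone, the change from 4-fluorophenyl to 4-methoxyphenyl is the first in this set that can be read at a single place, and it gives a 6.5-fold higher number from compound 3 to compound 4 (0.82 log units; beyond the scatter) in a comparison where everything else in the molecule stays the same. Within the data shown here, this position, on an aromatic carbon para to a large group, therefore does not tolerate every exchange without consequence: methoxy in place of fluoro produces a step beyond the scatter, and the earlier compounds, which differ from one another in several places, could not show this. The data shown offer no measurement that would explain the size of this step.

A single pair cannot separate what is particular to methoxy from what might hold for any group other than fluoro at this position. As far as these compounds go, it remains open whether hydroxy or ethoxy there would stay close to compound 3 or move further from it, and whether methoxy in place of fluoro would give a step of similar size with a different substitution on the benzamide part of the molecule.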